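A few compounds are considered here, and "the series" means these few. Any claim that something is new, unique, unknown or untested is made for them only; others in the source may bear on it.

Two measured compounds share one core. Compound 1 `CC(=O)Oc1ccc(-c2ccc(F)cc2F)cc1C(=O)NCc1ccccc1` carries a benzyl on the amide nitrogen, while compound 2 `CC(=O)Oc1ccc(-c2ccc(F)cc2F)cc1C(=O)Nc1ccccc1` carries a phenyl there. In a functional assay on the whole organism (Ear) for inhibition, with Mus musculus as the target, at a dose of 40 mg/kg by the oral route (on this read-out higher numbers stand for more inhibition at the one dose given (going by the name of the read-out) and lower numbers for less inhibition), compound 1 gives 34.1%. In this assay compound 2 gives 23.2%. Among the measured compounds shown here, the step of a number 10.9 percentage points lower from compound 1 to compound 2 (beyond the scatter) lies beyond the scatter, so compound 2 stands as the lower of the two numbers, with compound 1 as its only neighbour.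

Compound 3 `CC(=O)Oc1ccc(-c2ccc(F)cc2F)cc1C(=O)Nc1ccccc1C` differs from compound 2 by methyl in place of hydrogen on an aromatic carbon. For the measured compounds named here, no measured step adds a methyl to the ring on the amide nitrogen; the single measured step, phenyl in place of benzyl, is a different change and gives no direct guide. Without a bearing step, the expected change a number 2.8 percentage points higher from compound 2 to compound 3 (within the scatter) is none beyond the scatter. Compound 3 is therefore estimated at 26%, between 10% and 45%.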

Compound 3, a percentage reported as inhibition, in the whole organism at one dose (the size of the read-out at that dose, not a potency): 19.6%
For compound 3 the middle estimate is 6.4 percentage points above the measured one; measured number inside the range.
By their numbers in this assay, from the lowest: compounds 3 and 2 (each within the scatter of the next); then compound 1.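

Adding a methyl to an aromatic carbon of the phenyl on the amide nitrogen, ortho to a large group, gives in this assay a step of a number 3.6 percentage points lower from compound 2 to compound 3 (within the scatter), so at this dose this small addition cannot be told apart from no change. Against the benzyl group, the 2-methylphenyl group gives a number 14.5 percentage points lower from compound 1 to compound 3 (beyond the scatter), so the drop seen on going from benzyl to phenyl is not recovered by this methyl. No measurement on hand explains these numbers.

From the compounds shown here alone, it remains open whether a different group on this aromatic carbon, such as a methoxy group, a chlorine or an amine, would move the number beyond the scatter. Going by these compounds, it is also open whether a methyl on the benzyl ring of compound 1 would behave as it does here.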